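The source may hold more compounds than are shown below. What is called first, only, known or untested is meant among the compounds shown, and "the series" means these compounds.

Measured so far in an ADME assay on S9 fraction from liver (Homo sapiens) for metabolic stability, with a stated time of 1 h; on this read-out higher numbers stand for a more stable compound and lower numbers for a less stable compound:
- compound 1 `N#Cc1cnc(NCc2ccccc2C(F)(F)F)cc1N[C@H]1CC[C@@H](O)CC1`: 0%
- compound 2 `N#Cc1cnc(NCc2ccccc2C(F)(F)F)cc1N[C@H]1C[C@H](C(N)=O)C1`: 68%

Compound 1 stands lower of these two, at the bottom of what this read-out can show. Going by the values given here, the only measured step, a number 68 percentage points higher from compound 1 to compound 2 (beyond the scatter), is large and beyond the scatter. It puts 3-carbamoylcyclobutyl in place of 4-hydroxycyclohexyl on a nitrogen.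

Compound 3 `N#Cc1cnc(NCc2ccccc2)cc1N[C@H]1CC[C@@H](O)CC1` keeps that 4-hydroxycyclohexyl. It differs from compound 1 elsewhere, with hydrogen in place of trifluoromethyl on an aromatic carbon. Among the compounds with values here, the measured step therefore changes a different place and gives no size for this change, and no measured pair shows this swap directly.

Compound 1 reads 0%, so a fall cannot be seen in this assay and any visible change would be upward. With the 4-hydroxycyclohexyl still in place, only a small rise is expected, within the scatter: a number 5 percentage points higher from compound 1 to compound 3 (within the scatter). For compound 3 the estimated value is 5%, with an expected range from 0% to 20%.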

Compound 3, percent of the compound remaining: 45%
Estimate against measurement, compound 3: 40 percentage points below; measured number above the stated range.
By their numbers in this assay, from the lowest: compound 1; then compound 3; then compound 2.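

In this assay the trifluoromethyl on the aromatic carbon turns out to count for a great deal: with hydrogen in its place there is a number 45 percentage points higher from compound 1 to compound 3 (beyond the scatter) and this large step comes from a change at a spot the earlier pair left untouched. The 4-hydroxycyclohexyl therefore does not hold the number at the bottom of the scale on its own, as compound 3 keeps that group and still gives 45% in the same test, so the earlier step from swapping that ring group is no longer the only route to a higher number. Nothing measured here explains why removing the trifluoromethyl has so large an effect on this read-out.

The compounds shown leave open how a single fluorine, a methyl or a methoxy group on that aromatic carbon would read, given that only trifluoromethyl and hydrogen appear there. Also open, going by these compounds, is what the 3-carbamoylcyclobutyl would give with hydrogen on that carbon, and whether the two changes together would add up to more than either one alone.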